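The source may report more compounds than this note shows. Statements on the series, on what has been measured and on what is new or still open speak of the compounds shown alone.

Among the measured compounds shown here, compound 1 `Oc1cccc2c1CCCC2c1c[nH]cn1` is the one member of the series with a number in an assay on isolated protein (Cricetulus griseus) for binding affinity to Alpha-1B adrenergic receptor (Mesocricetus auratus), read by radioligand binding; on this read-out lower numbers stand for stronger inhibition and higher numbers for weaker inhibition: here compound 1 gives 145 nM. Compound 2 `CS(=O)(=O)Nc1ccc(Cl)c2c1CCCC2c1c[nH]cn1` returns only a limit in this assay, < 10000 nM. Compound 3 `CCS(=O)(=O)Nc1cccc2c1CCCC2CNC` likewise returns only a limit, < 10000 nM. The picture is therefore set by the limit of < 10000 nM in this assay, at which 2 of the 3 values shown sit, with compound 1 standing alone with a measured value.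

Compound 4 `COC(=O)Nc1cccc2c1CCCC2c1c[nH]cn1` is the next member to be measured in this assay. Its change from compound 1 is (methoxycarbonyl)amino in place of hydroxy on an aromatic carbon. For the measured compounds named here, no step between two measured compounds is available to size this change, so the expectation rests on the fact that only compound 1, carrying hydroxy, has given a number, 145 nM. Compound 2, which does not carry hydroxy, returned only a limit. Compound 3, which also does not carry hydroxy, returned only a limit as well. The step from compound 1 to compound 4 is therefore expected to weaken binding, an 8.3-fold higher number from compound 1 to compound 4 (0.92 log units; beyond the scatter), beyond the usual scatter. For compound 4 the estimate in this assay is 1200 nM, with a range from 200 nM to 8000 nM.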

Compound 4, inhibition constant: 10000 nM
For compound 4 the middle estimate is 8.3-fold (0.92 log units) below the measured one; the whole stated range lies below it.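

The hydroxy position now has its first sized change: putting (methoxycarbonyl)amino in place of hydroxy on this aromatic carbon gives a 69-fold higher number from compound 1 to compound 4 (1.84 log units; beyond the scatter) in this assay. This is the only pair shown that differs in one place, so the effect of this replacement is now read directly and no longer rests on compounds that differ in more than one place. The value of compound 4 stands at the same figure as the assay limit in this set: the limit of < 10000 nM in this assay, at which 2 of the 4 values shown sit.

The compounds shown do not tell whether any other group on this aromatic carbon keeps a value near that of compound 1, 145 nM. A plain amine or a methoxy group there would help show whether the loss follows the nitrogen, the carbonyl or the entering group as a whole.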